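The compounds below may be only part of what the source reports. "The series", "measured", "known", "first", "only" and "open" are said of these compounds alone.

In a functional assay on U-937 cells (Homo sapiens) for antiproliferative activity, read by CCK-8 assay, with a stated time of 24 h (on this read-out higher numbers stand for weaker inhibition and lower numbers for stronger inhibition), compound 1 `CC1CCN(Cc2ccc3nc(NC(=O)N/N=C/c4ccccn4)sc3c2)CC1` gives 21500 nM. Compound 2 `C/C(=N\NC(=O)Nc1nc2ccc(CN3CCC(C)CC3)cc2s1)c1cnccn1` gives > 40000 nM, which is a limit of the assay and not a number. Compound 3 `C/C(=N\NC(=O)Nc1nc2ccc(CN3CCC(C)CC3)cc2s1)c1ccccc1` carries phenyl in place of pyrazin-2-yl on a carbon with a double bond to nitrogen. Among the compounds with values here, the only measured step that bears on this change is an at least 1.8-fold higher number from compound 1 to compound 2 (0.26 log units; that floor lies within the scatter), which also alters an aromatic ring and ends at the limit. Within the data shown here, with compound 1 at 21500 nM as the sole measured number, a modest move to stronger inhibition in this assay is expected. A second limit remains possible for compound 3. The expected step is an at least 1.6-fold lower number from compound 2 to compound 3 (0.22 log units; that floor lies within the scatter). For compound 3 the estimated value is 24000 nM, with an expected range of 9000 nM to 45000 nM.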

Compound 3, half-maximal inhibitory concentration: > 40000 nM
Compound 3: only a limit was reported; the forecaster's own chance of this, stated with the estimate: 35%; at least 1.6-fold (0.22 log units) between middle value and limit.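

In this assay compound 3, with phenyl in place of pyrazin-2-yl on a carbon with a double bond to nitrogen, gives > 40000 nM, which is a limit of the assay and not a number. The step between compound 2 and compound 3 cannot be read, because both stand at the same limit: the limit of > 40000 nM in this assay, at which 2 of the 3 values shown sit. Within the data shown here, the only readable step is an at least 1.8-fold higher number from compound 1 to compound 3 (0.26 log units; that floor lies within the scatter), so on this carbon phenyl, like pyrazin-2-yl, yields no measured number. The compounds shown leave open whether a phenyl ring carrying an amine or a carboxylic acid at this place would give a value within the range of this assay.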